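The source may report more compounds than this note shows. Statements on the series, on what has been measured and on what is new or still open speak of the compounds shown alone.

Compound 2 `Cc1nc(N)nc(N[C@@H]2C[C@H](CO)[C@@H](O)[C@H]2O)c1-c1nc2ccccc2s1` gives 4000 nM in an ADME assay on cells (Homo sapiens) for cytotoxicity, read by polymerase chain reaction, with a stated time of 3 days; on this read-out lower numbers stand for higher toxicity in this test and higher numbers for lower toxicity in this test. Compound 1 `Nc1nc(Cl)c(-c2nc3ccccc3s2)c(N[C@@H]2C[C@H](CO)[C@@H](O)[C@H]2O)n1` gives 14000 nM in this assay. For compound 3 `CCc1nc(N(C)C)nc(N[C@@H]2C[C@H](CO)[C@@H](O)[C@H]2O)c1-c1nc2ccccc2s1` this assay reports only a limit, > 25000 nM.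

Of the two numbers shown, compound 2 holds the lower one, and the only measured step is a 3.5-fold lower number from compound 1 to compound 2 (0.54 log units; beyond the scatter). Compound 4 `CCOC(=O)NCCNc1nc(C)c(-c2nc3ccccc3s2)c(N[C@@H]2C[C@H](CO)[C@@H](O)[C@H]2O)n1` differs from compound 2 by 2-((ethoxycarbonyl)amino)ethyl in place of hydrogen on a nitrogen on an aromatic ring. The measured step concerns a change at another place on the shared core, so it gives no direct guide to this one. Compound 3 also carries substituents on that nitrogen and sits at the limit of > 25000 nM in this assay, at which 1 of the 3 values shown sits. For compound 4 the result in this assay is therefore expected near 8000 nM, between 2500 nM and 25000 nM. The expected step is a 2.0-fold higher number from compound 2 to compound 4 (0.30 log units; within the scatter).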

Compound 4, half-maximal cytotoxic concentration: 12000 nM
Estimate against measurement, compound 4: 1.5-fold (0.18 log units) below; measured number inside the range.
By their numbers in this assay, from the lowest: compound 2; then compounds 4 and 1 (each within the scatter of the next). At a limit, above all of these: compound 3.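

In this assay, the step at this nitrogen is a 3.0-fold higher number from compound 2 to compound 4 (0.48 log units; beyond the scatter), so substitution here moves the number towards lower toxicity in this test. Compound 3 also carries substituents on that nitrogen, but it differs from compound 2 in other places too, and its value is only a limit: the limit of > 25000 nM in this assay, at which 1 of the 4 values shown sits.

One chain cannot show which part of 2-((ethoxycarbonyl)amino)ethyl matters. On these data alone, whether a plain ethyl group, a longer chain, or a chain ending in an amine or a carboxylic acid would shift the number the same way remains open.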